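Three inactive analogues and a fourth with two halogens

The compounds below may be only part of what the source reports. "The series", "measured", "known", "first", "only" and "open" are said of these compounds alone.

Compound 1 `Cc1cccc(CNc2ncnc3c2ncn3[C@@H]2O[C@H](CO)[C@@H](O)[C@H]2O)c1` stands at the edge of what a functional assay on G-361 cells (Homo sapiens) for antiproliferative activity, with a stated time of 72 h (a lower number here means a stronger inhibitor, a higher number a weaker inhibitor), can report: compound 1 gives > 166000 nM, which is a limit of the assay and not a number. Compound 2 `OC[C@H]1O[C@@H](n2cnc3c(NCc4cc(F)cc(F)c4)ncnc32)C(O)C1O` also gives only a limit in this assay, > 166000 nM. Compound 3 `OC[C@H]1O[C@@H](n2cnc3c(NCc4c(F)ccc(F)c4F)ncnc32)[C@H](O)[C@@H]1O` likewise gives a limit, > 166000 nM. The step that the two limits leave unreadable from compound 1 to compound 3 cannot be sized because both values sit at the limit of > 166000 nM in this assay, at which 3 of the 3 values shown sit. Compound 4 `OC[C@H]1O[C@@H](n2cnc3c(NCc4ccc(F)c(Cl)c4)ncnc32)[C@H](O)[C@@H]1O` differs from compound 1 by 3-chloro-4-fluorophenyl in place of 3-methylphenyl on a saturated chain carbon bound to a nitrogen on an aromatic ring. Among the compounds with values here, no measured step bears readably on this change, and with every value shown at the limit, compound 4 is expected to give an estimated 166000 nM in this assay, between 30000 nM and 1000000 nM. The expected step of a number no higher from compound 1 to compound 4 (the limit leaves the size open) is therefore estimated as none readable, most likely another limit.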

Compound 4, half-maximal inhibitory concentration: > 166000 nM
Compound 4: no number, only a limit (the forecaster's own chance of this, stated with the estimate: 85%); the middle value lies on the limit itself.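

The steps to compound 4 from compound 1 and from compound 3 cannot be read, as all of these compounds give only a limit: the limit of > 166000 nM in this assay, at which 4 of the 4 values shown sit.

The compounds shown leave open whether any change to the benzyl group on the shared core would give a readable number in this assay at all.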